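Aryl exchange on the shared core: expectation for compound 3

The compounds below may be only part of what the source reports. "The series", "measured", "known", "first", "only" and "open" are said of these compounds alone.

In a functional assay on MCF7 cells (Homo sapiens) for inhibition, read by MTT assay, with a stated time of 48 h (on this read-out lower numbers stand for stronger inhibition and higher numbers for weaker inhibition), compound 2 `COc1ccc(OC)c(C(c2c[nH]c3ccc(Br)cc23)c2c[nH]c3ccc(Br)cc23)c1` gives 2800 nM, level with compound 1 `Oc1cccc(C(c2c[nH]c3ccc(Br)cc23)c2c[nH]c3ccc(Br)cc23)c1`, which gives 2800 nM. Among the measured compounds shown here, the only measured step, no change at the digits printed from compound 1 to compound 2 (within the scatter), shows that swapping the group on the saturated chain carbon bound to two aromatic carbons left the read-out unchanged. Compound 3 `O=[N+]([O-])c1ccc(C(c2c[nH]c3ccc(Br)cc23)c2c[nH]c3ccc(Br)cc23)cc1` repeats such a swap: 4-nitrophenyl in place of 2,5-dimethoxyphenyl on a saturated chain carbon bound to two aromatic carbons. For the measured compounds named here, since the one step that bears on this change was flat, the step of no change at the digits printed from compound 2 to compound 3 (within the scatter) is expected to stay within the scatter. Compound 3 is therefore estimated at 2800 nM, with a range from 900 nM to 9000 nM.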

Compound 3, half-maximal inhibitory concentration: 3100 nM
Compound 3: middle estimate off by 1.1-fold (0.04 log units), on the low side; the range from low to high includes it.
By their numbers in this assay, from the lowest: compounds 1, 2 and 3 (each within the scatter of the next).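

In this assay the exchange for 4-nitrophenyl gives a 1.1-fold higher number from compound 2 to compound 3 (0.04 log units; within the scatter) and a 1.1-fold higher number from compound 1 to compound 3 (0.04 log units; within the scatter) and so leaves the series flat. On the saturated chain carbon bound to two aromatic carbons, the read-out now stays level across three different substituted phenyl groups, one of which brings in nitrogen and a double bond outside aromatic rings.

Still open, from the compounds shown here alone, is whether this flatness extends to groups other than substituted phenyl at this carbon, such as a carboxylic acid, an amine or a longer alkyl chain. No measurement at hand accounts for the flat read-out.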